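The source may hold more compounds than are shown below. What is called first, only, known or untested is meant among the compounds shown, and "the series" means these compounds.

Measured compounds:
Compound 1, `CN(C)C(=O)/C=C/c1ccc2noc(-c3ccccc3)c2c1`, gives 40300 nM in an assay for inhibition of inositol hexakisphosphate kinase 2 (Homo sapiens), read by colorimetric assay, coupled enzyme assay and malachite green, with a stated time of 120 min, in the presence of a further agent that is not named here; on this read-out higher numbers stand for weaker inhibition and lower numbers for stronger inhibition.
Compound 2, `O=C(O)c1ccc2noc(-c3ccc(N4CCCCC4)cc3)c2c1`, gives 240 nM in this assay.

Of the two numbers, compound 2 holds the lower one; compound 1 stands at a higher number by a margin well beyond the scatter, so of these two compound 2 is the stronger inhibitor in this assay. The two compounds differ in more than one place, so their gap cannot be assigned to a single change.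

Compound 3, `O=C(O)c1ccc2noc(-c3ccc(Oc4ccccn4)cc3)c2c1`, has not yet been measured. It differs from compound 2 in one place: (pyridin-2-yl)oxy in place of piperidin-1-yl on an aromatic carbon. Among the measured compounds shown here, no measured pair in this set differs in only one place, so there is no step of known size to lean on, and the expectation rests on the structural change alone. The group that enters is similar in size to the one that leaves and sits at the same place on the same core, so the step from compound 2 to compound 3 is expected to be small and toward a higher number, a 2.5-fold higher number from compound 2 to compound 3 (0.40 log units; beyond the scatter), with wide uncertainty. Compound 3 is therefore estimated at 600 nM in this assay, within a range from 120 nM to 4000 nM.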

Compound 3, half-maximal inhibitory concentration: 1190 nM
Compound 3: the middle estimate sits 2.0-fold (0.30 log units) below what was measured; the measured number falls inside the stated range.
By their numbers in this assay, from the lowest: compound 2; then compound 3; then compound 1.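

Among the compounds shown here, compound 2 and compound 3 form the first pair in the set that differs in one place, so the effect of a change on an aromatic carbon para to a large group can now be read directly. In this assay, exchanging piperidin-1-yl for (pyridin-2-yl)oxy gives a 5.0-fold higher number from compound 2 to compound 3 (0.70 log units; beyond the scatter), which shows that inhibition responds to the group at this position but is not lost with this change. The exchange replaces a non-aromatic ring with an aromatic ring joined through oxygen, and no measurement given here explains the size of the step.

The entering group differs from the leaving one in its ring, its oxygen link and its heavy-atom and hydrogen-bond acceptor counts all at once, so the step cannot be divided among these features; a phenoxy group or a piperidin-4-yloxy group at the same position would address that question. From the compounds shown here alone, the part played by the carboxylic acid also remains open, as compound 2 and compound 3 both carry it.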